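Aryl exchange in a cytotoxicity series of acids

A few compounds are considered here, and "the series" means these few. Any claim that something is new, unique, unknown or untested is made for them only; others in the source may bear on it.

Compound 1 `Cc1ccc(/C=C2\CC[C@H]3C(C)(C)CCC[C@]3(C)[C@H]2CCC(C)CC(=O)O)cc1` gives > 200000 nM in a functional assay on MCF7 cells (Homo sapiens) for cytotoxicity, read by MTT assay, with a stated time of 24 h (on this read-out higher numbers stand for weaker inhibition and lower numbers for stronger inhibition), which is a limit of the assay and not a number.
Compound 2 `CC(CC[C@H]1/C(=C/c2ccc([N+](=O)[O-])cc2)CC[C@H]2C(C)(C)CCC[C@]12C)CC(=O)O` gives > 200000 nM in this assay, again only a limit.

Compound 2 therefore stands at the limit, where (the limit of > 200000 nM in this assay, at which 2 of the 2 values shown sit). Among the compounds with values here, the single measured step, a step that the two limits leave unreadable from compound 1 to compound 2, is unreadable for the same reason. Compound 3 `COc1ccc(/C=C2\CC[C@H]3C(C)(C)CCC[C@]3(C)[C@H]2CCC(C)CC(=O)O)cc1OC` differs from compound 2 by 3,4-dimethoxyphenyl in place of 4-nitrophenyl on a double-bonded chain carbon bound to a double-bonded ring carbon. Within the data shown here, no measured step bears readably on this change, so no direction in this assay can be drawn from the measured pair. Compound 3 is expected to give about 200000 nM, within 50000 nM to 800000 nM, most likely reported again as a limit. The expected step is a number no higher from compound 2 to compound 3 (the limit leaves the size open).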

Compound 3, half-maximal inhibitory concentration: > 200000 nM
Compound 3 gave a limit, no number; the forecaster's own chance of this, stated with the estimate: 75%; the middle value sits exactly at the limit.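

No new step can be read for compound 3 against compound 1 or compound 2, as all three values are limits and not numbers: the limit of > 200000 nM in this assay, at which 3 of the 3 values shown sit.

Going by these compounds, whether any aryl group on the shared core gives a numerical value in this assay remains open.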